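The source may hold more compounds than are shown below. What is called first, only, known or untested is meant among the compounds shown, and "the series" means these compounds.

Measured compounds:
- compound 1 `Cc1ccc(-c2nn(-c3ccccc3)cc2CNc2ccccc2)cc1` — in an ADME assay on Vero 76 cells (Chlorocebus sabaeus) for cytotoxicity, read by MTT assay, with a stated time of 96 h (on this read-out lower numbers stand for higher toxicity in this test and higher numbers for lower toxicity in this test), compound 1 gives 52000 nM
- compound 2 `Clc1ccc(NCc2cn(-c3ccccc3)nc2-c2ccc(Cl)cc2)cc1` — in this assay compound 2 gives 90000 nM

Compound 1 and compound 2 thus sit close together; the two values lie within the usual scatter of each other, so neither can be called the more or less toxic one. Compound 3 `Cc1ccc(-c2nn(-c3ccccc3)cc2CNc2ccc(Br)cc2)cc1` is not yet measured. It differs from compound 1 in one place: bromo in place of hydrogen on an aromatic carbon. For the measured compounds named here, no measured pair shows this change, so the data give no guide to its effect. Compound 3 is expected to stay close to compound 1, with a step of a 1.0-fold lower number from compound 1 to compound 3 (0.02 log units; within the scatter) that does not exceed the scatter. The estimate for compound 3 is 50000 nM, ranging from 22000 nM to 110000 nM.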

Compound 3, half-maximal cytotoxic concentration: 92000 nM
Beside the measured number, compound 3's estimate is 1.8-fold (0.26 log units) below it; the range from low to high includes it.
By their numbers in this assay, from the lowest: compounds 1, 2 and 3 (each within the scatter of the next).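

In this assay, the change from anilino to (4-bromophenyl)amino gives a 1.8-fold higher number from compound 1 to compound 3 (0.25 log units; within the scatter). Bromo on this aromatic carbon, para to a large group, therefore leaves compound 3 indistinguishable from compound 1 in this read-out, with no clear shift in toxicity. Nothing available explains this result.

As far as these compounds go, whether an amine or a carboxylic acid at this same place would move the number beyond the scatter remains open. So does whether bromo would behave alike on the other aromatic rings of the shared core.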